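A few compounds are considered here, and "the series" means these few. Any claim that something is new, unique, unknown or untested is made for them only; others in the source may bear on it.

Compound 1 `CCN(C[C@H]1CC[C@H](N)CC1)c1nccc(Nc2cc([C@H]3CCN(C)C3=O)[nH]n2)n1`: 621 nM
Compound 2 `CN1CC(C)(C)C(c2cc(Nc3ccnc(N(C)C[C@H]4CC[C@H](N)CC4)n3)n[nH]2)C1=O`: > 2900 nM
Compound 3 `COCC(C)c1cc(Nc2ccnc(N(C)Cc3ccc4[nH]cnc4c3Cl)n2)n[nH]1`: 617 nM

Going by the values given here, in an assay on isolated protein for inhibition of serine/threonine-protein kinase PAK 4 (Homo sapiens) (on this read-out higher numbers stand for weaker inhibition and lower numbers for stronger inhibition), compound 1 gives 621 nM, one of only two numbers recorded here; the other, compound 3 at 617 nM, lies within the scatter of it, so the two cannot be told apart. Compound 2 reaches only a limit of the assay, > 2900 nM, and so sits at the limit of > 2900 nM in this assay, at which 1 of the 3 values shown sits. Compound 4 `CN1CC[C@H](c2cc(Nc3ccnc(NC[C@H]4CC[C@H](N)CC4)n3)n[nH]2)C1=O` differs from compound 1 in one place: hydrogen in place of ethyl on a nitrogen on an aromatic ring. Among the compounds with values here, no measured pair differs in just this way, so the step is judged without precedent. A step of modest size at most is expected, with a slight lean toward a higher number. Compound 4 is therefore estimated at 900 nM, within 300 nM to 2900 nM. That estimate means a step of a 1.4-fold higher number from compound 1 to compound 4 (0.16 log units; within the scatter) is expected.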

Compound 4, inhibition constant: 1270 nM
Compound 4: middle estimate off by 1.4-fold (0.15 log units), on the low side; measured number inside the range.
By their numbers in this assay, from the lowest: compounds 3 and 1 (each within the scatter of the next); then compound 4. At a limit, above all of these: compound 2.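

With a single change at this nitrogen on the aromatic ring, hydrogen in place of ethyl, this assay shows a 2.0-fold higher number from compound 1 to compound 4 (0.31 log units; beyond the scatter). Going by these compounds alone, this is the first step here that can be read at this place, and it is modest in size but beyond the scatter, so the ethyl group is not interchangeable with hydrogen on this read-out. Nothing shown here accounts for the step. Going by these compounds, whether a propyl or a hydroxyethyl chain on this nitrogen would give a lower or a higher number remains open.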